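The compounds below may be only part of what the source reports. "The series", "measured", "known", "first", "only" and "open" are said of these compounds alone.

Working notes on the series. In an in vitro assay on LLC-PK1 cells for displacement of a labelled ligand from growth hormone secretagogue receptor type 1 (Homo sapiens) (a higher number here means a weaker inhibitor, a lower number a stronger inhibitor), compound 1 `COc1ccc(Cn2c(CCc3ccccc3)nnc2[C@H](NC(=O)c2ccccn2)c2c[nH]c3ccccc23)cc1` gives 0.7 nM, while compound 2 `COc1ccc(Cn2c(CCc3c[nH]c4ccccc34)nnc2[C@H](NC(=O)Cc2ccncc2)c2c[nH]c3ccccc23)cc1` gives 76 nM; compound 2 thus holds the higher of the two numbers, and its gap to compound 1 lies beyond the scatter. The two differ in more than one place, so neither difference can be read off on its own from these two values. Compound 3 `COc1ccc(Cn2c(CCc3ccccc3)nnc2[C@H](NC(=O)Cc2ccncc2)c2c[nH]c3ccccc23)cc1` is not yet measured; it keeps the amide of compound 2 and takes the change (phenyl in place of 1H-indol-3-yl on a saturated chain carbon, two bonds along the chain from an aromatic carbon), which leaves it with the same chain as compound 1. Direction in this assay is uncertain: the only compound with the phenethyl chain, compound 1, sits at 0.7 nM, but with a different amide. A decrease beyond the scatter is expected for the step of a 3.8-fold lower number from compound 2 to compound 3 (0.58 log units; beyond the scatter), though smaller than the full gap between the two measured compounds. Compound 3 is estimated at 20 nM, within 3 nM to 150 nM.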

Compound 3, half-maximal inhibitory concentration: 270 nM
For compound 3 the middle estimate is 14-fold (1.13 log units) below the measured one, and the stated range ends below it.
By their numbers in this assay, from the lowest: compound 1; then compound 2; then compound 3.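

Holding the amide of compound 2 fixed, phenyl in place of 1H-indol-3-yl gives a 3.6-fold higher number from compound 2 to compound 3 (0.55 log units; beyond the scatter) in this assay, so with this amide the 2-(1H-indol-3-yl)ethyl chain carries the lower number. With the phenethyl chain held fixed, (pyridin-4-yl)methyl in place of pyridin-2-yl on a carbonyl carbon gives a 390-fold higher number from compound 1 to compound 3 (2.59 log units; beyond the scatter) as the larger of the two steps, which ties the low number of compound 1 to its amide and not to its chain. Nothing measured here gives a reason for either step.

From the compounds shown here alone, whether the chain step keeps its direction with the pyridin-2-yl amide remains open. So does the outcome for pyridin-4-yl placed directly on the carbonyl carbon, or for a longer chain such as 3-phenylpropyl.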